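Ester aryl substituent swap on the shared core

The source may hold more compounds than are shown below. What is called first, only, known or untested is meant among the compounds shown, and "the series" means these compounds.

Among the compounds with values here, compound 3 `COc1ccc(C(=O)Oc2cc3c(C)ccc(C(C)C)c3cc2C)cc1` gives 93.4% in a functional assay on MCF7 cells (Homo sapiens) for antiproliferative activity, read by sulforhodamine B assay, with a stated time of 48 h, tested at 50 uM (on this read-out lower numbers stand for less inhibition and higher numbers for more inhibition at the one concentration tested (going by the name of the read-out)), the highest of the three numbers measured so far. Compound 1 `COc1ccc(C(=O)Oc2cc3c(cc2C)[C@@H](C(C)C)CC=C3C)cc1` gives 80.1% in this assay, and compound 2 `CC1=CC[C@H](C(C)C)c2cc(C)c(OC(=O)c3ccc(Cl)cc3)cc21` gives 79.7%; both sit below compound 3 by more than the scatter. Within the data shown here, the one measured single-point step, a number 0.4 percentage points lower from compound 1 to compound 2 (within the scatter), exchanges the group on the ester aryl at the same place as the step now considered and stays within the scatter. Compound 4 `Cc1cc2c(C(C)C)ccc(C)c2cc1OC(=O)c1ccc([N+](=O)[O-])cc1` differs from compound 3 by nitro in place of methoxy on an aromatic carbon. Nitro has no measured precedent in this series, so the expectation rests on the chloro-for-methoxy step alone, which suggests that a swap at this place on the ester aryl leaves the inhibition about where it was. Compound 3 with 93.4% also leaves little room upward. The expected step is therefore a number 5.4 percentage points lower from compound 3 to compound 4 (within the scatter) in this assay, a change expected to lie within the scatter, with some allowance downward for the lack of any nitro analogue. Compound 4 is expected to give 88% in this assay, with a range from 70% to 97%.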

Compound 4, a percentage reported as inhibition, at one concentration (the size of the read-out at that concentration, not a potency): 100%
Compound 4: middle estimate off by 12 percentage points, on the low side, and the stated range ends below it.
By their numbers in this assay, from the lowest: compounds 2 and 1 (each within the scatter of the next); then compounds 3 and 4 (each within the scatter of the next).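

The step of a number 6.6 percentage points higher from compound 3 to compound 4 (within the scatter) in this assay extends the picture at this place on the ester aryl: 4-methoxyphenyl to 4-nitrophenyl on the core of compound 3 leaves the inhibition within the scatter, just as the chloro exchange does on the core of compound 1 in a number 0.4 percentage points lower from compound 1 to compound 2 (within the scatter). Two different replacements of methoxy, on two different cores, have now been read at this place, and neither step goes beyond the scatter; no compound shown goes against this, though two steps make only a narrow basis. Compound 4 at 100% also stands at the top of a percentage scale, so at this one concentration the read-out can show nothing further upward, and it does not separate compound 3 from compound 4 in potency. Nothing on hand bears on why the nitro compound reads as it does.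

From the compounds shown here alone, whether an amine or a carboxylic acid at this place on the ester aryl would also hold the inhibition remains open. So does whether chloro on the core of compound 3, or nitro on the core of compound 1, would behave as these two steps do.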